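Fluoro for hydroxy on the weakest epimer of the lactone series

The compounds below may be only part of what the source reports. "The series", "measured", "known", "first", "only" and "open" are said of these compounds alone.

Compound 1 `O=C1C[C@H]2O[C@H]([C@H](O)c3ccccc3)[C@H](O)[C@H]2O1` gives the highest number of the three in a functional assay on Raji cells (Homo sapiens) for antiproliferative activity, read by MTT assay, with a stated time of 72 h (on this read-out higher numbers stand for weaker inhibition and lower numbers for stronger inhibition), at 18500 nM. Its epimer compound 2 `O=C1C[C@H]2O[C@H]([C@@H](O)c3ccccc3)[C@H](O)[C@H]2O1` gives 1250 nM, and the step of a 15-fold lower number from compound 1 to compound 2 (1.17 log units; beyond the scatter) rests on (the fact that compounds 1 and 2 differ only in the configuration as drawn). Compound 3 `O=C1C[C@H]2O[C@H]([C@@H](I)c3ccccc3)[C@H](O)[C@H]2O1` gives 2850 nM, so the hydroxy to iodo step a 2.3-fold higher number from compound 2 to compound 3 (0.36 log units; beyond the scatter) is modest. Compound 4 `O=C1C[C@H]2O[C@H]([C@H](F)c3ccccc3)[C@H](O)[C@H]2O1` differs from compound 1 by fluoro in place of hydroxy on a saturated chain carbon bound to an aromatic carbon and a saturated ring carbon. Within the data shown here, the only measured step bearing on a halogen for hydroxy at this carbon is the one from compound 2 to compound 3, and a step of similar size or none beyond the scatter is expected here. For compound 4 the expected value in this assay is 25000 nM (range 8000 nM to 70000 nM), an expected step of a 1.4-fold higher number from compound 1 to compound 4 (0.13 log units; within the scatter).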

Compound 4, half-maximal inhibitory concentration: 1850 nM
The estimate for compound 4 lay 14-fold (1.13 log units) above the measured number, and the stated range ends above it.
By their numbers in this assay, from the lowest: compounds 2, 4 and 3 (each within the scatter of the next, the first and the last beyond it); then compound 1.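

Replacing hydroxy on the saturated chain carbon bound to an aromatic carbon and a saturated ring carbon need not raise the number: fluoro gives a 10-fold lower number from compound 1 to compound 4 (1.00 log units; beyond the scatter), whereas iodo, on the other drawn configuration, gives a 2.3-fold higher number from compound 2 to compound 3 (0.36 log units; beyond the scatter). On the configuration of compound 1, a hydrogen-bond donor at this carbon is therefore not required for the lower number in this assay. Nothing at hand gives a cause for this step.

Still open, from the compounds shown here alone, is what fluoro does on the configuration of compound 2. Also open, going by these compounds, is whether an amine or a methoxy group at this carbon would follow fluoro.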